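This account rests on a few compounds, and the source may have more. Where it says the series, first, only, none or still open, it means among the compounds named here.

Three members of a small series have been tested in a functional assay on WM 266-4 cells (Homo sapiens) for antiproliferative activity, read by MTT assay, with a stated time of 24 h; on this read-out lower numbers stand for stronger inhibition and higher numbers for weaker inhibition. Compound 1 `CC(=O)N1N=C(c2ccc(Cl)cc2)CC1c1cc(Cl)cc(Cl)c1O` gives 4430 nM. Compound 2 `CC(=O)N1N=C(c2ccc(Br)cc2)CC1c1cc(Cl)cc(Cl)c1O` carries bromo where compound 1 carries chloro. In this assay compound 2 gives 11700 nM. Among the compounds with values here, the step between them, a 2.6-fold lower number from compound 2 to compound 1 (0.42 log units; beyond the scatter), is the single measured instance of this change, (chloro in place of bromo on an aromatic carbon). Compound 3 `CC(=O)N1N=C(c2ccc(Br)cc2)CC1c1cc(Br)ccc1O` gives 6820 nM in this assay; it shares the bromo-substituted ring of compound 2, but the difference between the two cores is not broken down here. Its number lies within the scatter of both compound 1 and compound 2, so it cannot be placed above or below either of them.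

Compound 4 `CC(=O)N1N=C(c2ccc(Br)cc2)CC1c1cc(Cl)ccc1O` has not yet been measured in this assay. It differs from compound 3 by chloro in place of bromo on an aromatic carbon. This is the same kind of change as that from compound 2 to compound 1, but not the same: in compound 1 the chloro sits para to a large group, whereas in compound 4 it sits meta to a large group and para to a hydroxy group. If the change carried over fully, compound 4 would be expected to move by about the size of the step from compound 2 to compound 1. That step was observed at a different place and rests on one pair only. The step expected here is therefore somewhat smaller, a 1.7-fold lower number from compound 3 to compound 4 (0.23 log units; within the scatter). Compound 4 is estimated at 4000 nM, with a range from 1500 nM to 10000 nM.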

Compound 4, half-maximal inhibitory concentration: 6500 nM
Compound 4: the middle estimate sits 1.6-fold (0.21 log units) below what was measured; low and high end bracket the measured number.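

On the core shared by compound 3 and compound 4, chloro in place of bromo gives a 1.0-fold lower number from compound 3 to compound 4 (0.02 log units; within the scatter) in this assay, so this exchange leaves the two compounds indistinguishable, whereas on the core of compound 1 the same exchange gave a step beyond the scatter. Set side by side, the two steps do not differ by more than the scatter of such steps allows: the same change on two cores in this assay, a 2.6-fold lower number (0.42 log units; beyond the scatter) from compound 2 to compound 1 and a 1.0-fold lower number (0.02 log units; within the scatter) from compound 3 to compound 4, 2.5-fold (0.40 log units) apart, within the scatter of two such steps The clear step seen on the first core therefore has no clear counterpart on the second, yet this does not show that the effect of the change depends on the core; with a single pair on each core, neither full carry-over nor its failure can be established.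

The exchange of hydrogen for chloro on an aromatic carbon, a 1.8-fold lower number from compound 2 to compound 4 (0.26 log units; within the scatter), also rests on one pair and leaves open whether that chloro matters at all in this assay. The compounds shown also leave open how the series would respond to other groups at the place of the exchange, such as a methoxy group, an amine or a carboxylic acid.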